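Morpholine Amide Expected to Sit Near Its Ring-Amide Siblings

This account rests on a few compounds, and the source may have more. Where it says the series, first, only, none or still open, it means among the compounds named here.

Of the compounds shown here, three sharing one core have been tested in a functional assay on the whole organism (strain Wistar) for inhibition, with Rattus norvegicus as the target, read by paw edema, with stated times of 60 min and 6 h, at a dose of 100 mg/kg by the oral route; a higher number here means more inhibition at the dose given (going by the name of the read-out), a lower number less inhibition. Compound 1 `CNC(=O)CC1CCc2cc(OC)c(OC)cc21` gives 24.1%. Compound 2 `COc1cc2c(cc1OC)C(CC(=O)N1CCCCC1)CC2` gives 31.5%, and compound 3 `COc1cc2c(cc1OC)C(CC(=O)N1CCNCC1)CC2` gives 33.3%. Compound 1 has the lowest of the three numbers, but the other two lie within the usual scatter of it: a number 7.4 percentage points higher from compound 1 to compound 2 (within the scatter), and a number 9.2 percentage points higher from compound 1 to compound 3 (within the scatter). The two ring amides also sit close together, a number 1.8 percentage points higher from compound 2 to compound 3 (within the scatter), so none of the three numbers can be called higher or lower than another.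

Compound 4 `COc1cc2c(cc1OC)C(CC(=O)N1CCOCC1)CC2` has not yet been measured in this assay. It differs from compound 1 in this way: morpholin-4-yl in place of methylamino on a carbonyl carbon. The two steps already seen bear directly on this, since piperidin-1-yl and piperazin-1-yl each took the place of the same methylamino group on the same carbonyl carbon, and both stayed within the scatter. A further six-membered ring amide is thus expected to behave alike. Compound 4 is expected to show a number 6.9 percentage points higher from compound 1 to compound 4 (within the scatter), a step no larger than the scatter. In this assay compound 4 is estimated to give 31%, with a likely range from 21% to 41%.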

Compound 4, a percentage reported as inhibition, in the whole organism at one dose (the size of the read-out at that dose, not a potency): 14.8%
Compound 4: middle estimate off by 16.2 percentage points, on the high side; measured number below the stated range.
By their numbers in this assay, from the lowest: compounds 4, 1, 2 and 3 (each within the scatter of the next, the first and the last beyond it).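

In this assay, the identity of the ring on the carbonyl carbon now matters: morpholin-4-yl gives a number 18.5 percentage points lower from compound 3 to compound 4 (beyond the scatter) and a number 16.7 percentage points lower from compound 2 to compound 4 (beyond the scatter), so the three six-membered ring amides do not all behave alike, a difference that compound 2 and compound 3 alone could not reveal. The comparison with the open-chain amide is less clear, since replacing methylamino with morpholin-4-yl gives a number 9.3 percentage points lower from compound 1 to compound 4 (within the scatter), which means that compound 4 and compound 1 cannot be placed in order. The data give no reason why compound 4 differs from the other two ring amides.

The compounds shown leave open whether thiomorpholin-4-yl, with sulfur in place of the morpholine oxygen, or the five-membered pyrrolidin-1-yl would group with compound 2 and compound 3 or with compound 4. Each number also comes from a single oral dose, so the series shows how much inhibition appears at that dose, not how potency changes across these amides.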